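Replacing a methylcyclohexyl amide with a methylpyridyl amide

The source may hold more compounds than are shown below. What is called first, only, known or untested is meant among the compounds shown, and "the series" means these compounds.

Measured so far:
Compound 1 `CC1CCC(C(=O)N2CCc3nc(C#Cc4ccccc4)sc3C2)CC1`: > 10000 nM
Compound 2 `CC1CCCC(C(=O)N2CCc3nc(C#Cc4ccccc4)sc3C2)C1`: > 10000 nM

In an assay on HEK293 cells for negative allosteric modulation of metabotropic glutamate receptor 5 (Homo sapiens), read by FLIPR, with a stated time of 1 h (a higher number here means a weaker inhibitor, a lower number a stronger inhibitor), compound 1 gives > 10000 nM, which is a limit of the assay and not a number. In this assay compound 2 gives > 10000 nM, also a limit rather than a number. Compound 2 therefore stands at the limit on the values shown, as does compound 1, and the step that the two limits leave unreadable from compound 1 to compound 2 cannot be read; the two values shown share (the limit of > 10000 nM in this assay, at which 2 of the 2 values shown sit).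

Compound 3 `Cc1cccc(C(=O)N2CCc3nc(C#Cc4ccccc4)sc3C2)n1` differs from compound 2 by 6-methylpyridin-2-yl in place of 3-methylcyclohexyl on a carbonyl carbon. Among the measured compounds shown here, no measured step bears on this change, since the only measured step is unreadable. The size and direction of the step in this assay cannot be predicted from the two limits, so a wide range is given. For compound 3 the estimated value is 5000 nM, from 500 nM to 20000 nM. This estimate means a step of an at least 2.0-fold lower number from compound 2 to compound 3 (0.30 log units; that floor lies within the scatter), expected but poorly grounded.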

Compound 3, half-maximal inhibitory concentration: > 10000 nM
Compound 3: a limit, no number; the forecaster's own chance of this, stated with the estimate: 50%; middle value at least 2.0-fold (0.30 log units) from the limit.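

Compound 3 gives > 10000 nM in this assay, which is a limit of the assay and not a number. The steps among compound 1, compound 2 and compound 3 therefore cannot be read: the limit of > 10000 nM in this assay, at which 3 of the 3 values shown sit. The compounds shown leave open whether these three groups on the carbonyl carbon differ at all in this assay.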